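A few compounds are considered here, and "the series" means these few. Any claim that something is new, unique, unknown or untested is made for them only; others in the source may bear on it.

Working notes on the series. In an ADME assay for permeability, using PAMPA (a lower number here means that the compound crosses the layer more slowly, a higher number that the compound crosses the layer faster), compound 1 `CC1(C)CC(c2c[nH]c3c(C(N)=O)cc(-c4ccccc4)cc23)CCS1(=O)=O` gives 330 nm/s and compound 2 `NC(=O)c1cc(-c2ccccc2)cc2c(C3CCN(S(=O)(=O)CCCN4CCCCC4)CC3)c[nH]c12` gives 240 nm/s, so compound 2 stands within the scatter of compound 1. Compound 3 `CCS(=O)(=O)N1CCC(c2c[nH]c3c(C(N)=O)cc(-c4ccccc4)cc23)CC1` differs from compound 2 by hydrogen in place of (piperidin-1-yl)methyl on a saturated chain carbon, two bonds along the chain from a sulfonyl sulfur. The same difference reads 3-(piperidin-1-yl)propyl to ethyl. Within the data shown here, no measured pair shows this change, so the direction is uncertain, but a modest rise in this assay is expected, perhaps not beyond the scatter. The expected change is a 1.8-fold higher number from compound 2 to compound 3 (0.24 log units; within the scatter). Compound 3 is estimated at 420 nm/s, with a range of 180 nm/s to 900 nm/s.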

Compound 3, apparent permeability: 250 nm/s
Compound 3: the middle estimate sits 1.7-fold (0.23 log units) above what was measured, and the stated range covers the measured number.
By their numbers in this assay, from the lowest: compounds 2, 3 and 1 (each within the scatter of the next).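

The swap of 3-(piperidin-1-yl)propyl for ethyl on the sulfonyl gives [ a 1.0-fold higher number from compound 2 to compound 3 (0.02 log units; within the scatter) ] in this assay, so compound 2 and compound 3 cannot be told apart in this read-out. At this position, the piperidine ring and its seven heavy atoms in all can therefore go without separating the pair, though this rests on a single pair. Nothing measured here accounts for this result.

Going by these compounds, whether a carboxylic acid or a primary amine at the chain end would separate from compound 3 in this assay remains open. The same holds for a longer unbranched alkyl chain.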